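The compounds below may be only part of what the source reports. "The series", "measured", "known", "first", "only" and "open" are said of these compounds alone.

Measured in an ADME assay on tissue (MIA PaCa-2 cells, Homo sapiens) for pharmacokinetics; a higher number here means that the compound lasts longer, a lower number that the compound disappears faster:
- compound 1 `N[C@@H](CC(=O)OC[C@H]1O[C@@H](n2cc(F)c(=O)[nH]c2=O)C[C@@H]1O)C(=O)O`: 0.273 h
- compound 2 `N[C@@H](CC(=O)OC[C@H]1O[C@@H](n2cc(F)c(=O)[nH]c2=O)C[C@@H]1OC(=O)C[C@H](N)C(=O)O)C(=O)O`: 0.188 h
- compound 3 `CC(C)[C@H](N)C(=O)OC[C@H]1O[C@@H](n2cc(F)c(=O)[nH]c2=O)C[C@@H]1OC(=O)[C@@H](N)C(C)C`: 0.14 h

Compound 2 lies within the scatter of both compound 1 and compound 3, so these numbers set no order among them. Compound 4 `N[C@@H](CC(=O)O[C@H]1C[C@H](n2cc(F)c(=O)[nH]c2=O)O[C@@H]1CO)C(=O)O` has not yet been measured. It differs from compound 2 by hydrogen in place of (2-amino-2-carboxyethyl)carbonyl on an oxygen on a saturated carbon, with hydrogen in place of (2-amino-2-carboxyethyl)carbonyl on an oxygen on a saturated carbon. Among the compounds with values here, the one measured step that bears on this is a 1.5-fold lower number from compound 1 to compound 2 (0.16 log units; within the scatter), where the same group is added at a different oxygen, and it stays within the scatter. No step beyond the scatter is therefore expected in this assay. The expected change is a 1.2-fold higher number from compound 2 to compound 4 (0.09 log units; within the scatter). For compound 4 the estimated half-life is 0.23 h, with an expected range from 0.11 h to 0.45 h.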

Compound 4, half-life: 0.535 h
Compound 4: the middle estimate sits 2.3-fold (0.37 log units) below what was measured; measured number outside the range, above it.
By their numbers in this assay, from the lowest: compounds 3, 2, 1 and 4 (each within the scatter of the next, the first and the last beyond it).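

In this assay, the removal of (2-amino-2-carboxyethyl)carbonyl from the hydroxymethyl oxygen gives a 2.8-fold higher number from compound 2 to compound 4 (0.45 log units; beyond the scatter), a modest step beyond the scatter. The same group at the other oxygen gives only a 1.5-fold lower number from compound 1 to compound 2 (0.16 log units; within the scatter), which stays within the scatter, so the two oxygens do not count alike for this group. Nothing available accounts for this difference. The compounds shown leave open whether the free hydroxymethyl itself matters, or whether a small acetyl group on that oxygen would give a similar half-life.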